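The source may hold more compounds than are shown below. What is called first, only, known or untested is meant among the compounds shown, and "the series" means these compounds.

Measured in a functional assay (Mus musculus) for inhibition, with a stated time of 5 days; a higher number here means a weaker inhibitor, a lower number a stronger inhibitor:
- compound 1 `O=C(O)/C=C/c1cn(-c2ccc(O)cc2)nc1-c1cc(O)ccc1O`: > 100000 nM (a limit, not a number)
- compound 2 `CCOC(=O)/C=C/c1cn(-c2ccc(O)cc2)nc1-c1ccc(O)c(O)c1`: 6200 nM
- compound 3 `CCOC(=O)/C=C/c1cn(-c2ccc(O)cc2)nc1-c1ccc(O)cc1`: 25000 nM

Of the two exact values, compound 3 at 25000 nM has the higher number, and so is the weaker inhibitor. Compound 4 `CCOC(=O)/C=C/c1cn(-c2ccc(O)cc2)nc1-c1cc(O)ccc1O` has not yet been measured in this assay. It keeps the core and the 2-(ethoxycarbonyl)ethenyl group of compound 3 but has 2,5-dihydroxyphenyl in place of 4-hydroxyphenyl on an aromatic carbon.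

Going by the values given here, one measured step bears on this change, a 4.0-fold higher number from compound 2 to compound 3 (0.61 log units; beyond the scatter), where a hydrogen replaces a hydroxy on an aromatic carbon. Read in reverse, it suggests that adding a hydroxy to this ring could lower the number by a modest amount. The hydroxy groups of compound 4 are arranged differently from those of compound 2, so this step is only a rough guide. Compound 1 carries 2,5-dihydroxyphenyl as well, but it lacks the 2-(ethoxycarbonyl)ethenyl group and offers no exact value for comparison.

A modest move to a lower number is therefore expected, a 3.6-fold lower number from compound 3 to compound 4 (0.55 log units; beyond the scatter). For compound 4 the estimated value is 7000 nM, with an expected range of 1800 nM to 28000 nM.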

Compound 4, half-maximal inhibitory concentration: 12000 nM
Beside the measured number, compound 4's estimate is 1.7-fold (0.23 log units) below it, within the range that was stated.
By their numbers in this assay, from the lowest: compounds 2 and 4 (each within the scatter of the next); then compound 3. At a limit, above all of these: compound 1.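

In this assay, 2,5-dihydroxyphenyl in place of 4-hydroxyphenyl gives a 2.1-fold lower number from compound 3 to compound 4 (0.32 log units; beyond the scatter), so at this place on the core a lower number now comes with a further hydroxy in two different arrangements on the ring, not just one. The two arrangements are not separated here, since 2,5-dihydroxyphenyl in place of 3,4-dihydroxyphenyl gives a 1.9-fold higher number from compound 2 to compound 4 (0.29 log units; within the scatter). With the 2,5-dihydroxyphenyl group held constant, ethyl in place of hydrogen on an oxygen next to a carbonyl group gives an at least 8.3-fold lower number from compound 1 to compound 4 (0.92 log units; beyond the scatter), a step that rests on a limit and not on a number: the limit of > 100000 nM in this assay, at which 1 of the 4 values shown sits.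

The compounds shown leave open whether a methoxy or an amine in place of either hydroxy on this ring would keep the number near those of compound 2 and compound 4, and whether the 4-hydroxyphenyl group that all of them share on the ring nitrogen contributes at all. They also leave open how a longer chain in place of the ethyl, or an amide in place of the ethoxycarbonyl, would compare with compound 4.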